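The source may hold more compounds than are shown below. What is called first, only, known or untested is meant among the compounds shown, and "the series" means these compounds.

Compounds measured so far:
compound 1 `COc1ccc(-c2nc(C)c(C(=O)CSc3nc(N)c(C#N)c(-c4ccc(OC)cc4)n3)s2)cc1` — 0.26%
compound 2 `Cc1nc(-c2ccc(Cl)cc2)sc1C(=O)CSc1nc(-c2cccc(Cl)c2)c(C#N)c(=O)[nH]1` — 12.5%
compound 3 `COc1ccc(-c2nc(SCC(=O)c3sc(-c4ccc(Cl)cc4)nc3C)nc(N)c2C#N)cc1` — 0.79%

In a functional assay on U-87MG ATCC cells for antiproliferative activity against U-87 MG (Homo sapiens), read by MTT assay, with a stated time of 48 h, tested at 100 uM (a lower number here means a stronger effect, a higher number a weaker effect of the compound at the concentration tested), compound 1 gives the lowest of the three numbers. Its nearest neighbour is compound 3, which differs by chloro in place of methoxy on an aromatic carbon and gives 0.79%; the step of a number 0.5 percentage points higher from compound 1 to compound 3 (within the scatter) lies within the scatter. Compound 2, built on a different core, gives 12.5%, a number that stands beyond the scatter from compound 1.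

The unmeasured compound 4 `COc1ccc(-c2nc(C)c(C(=O)CSc3nc(N)c(C#N)c(-c4ccccc4)n3)s2)cc1` is reached from compound 1 by hydrogen in place of methoxy on an aromatic carbon. Within the data shown here, no measured step matches this exchange: the only step on the same aromatic carbon, from compound 1 to compound 3, swaps methoxy for chloro and shows essentially nothing. Among the measured compounds shown here, that single step offers the sole guide here, and it argues that altering the group on this ring moves the number little. The step of a number 2.2 percentage points higher from compound 1 to compound 4 (within the scatter) in this assay is therefore expected to stay within the scatter, if anything drifting upward.

Compound 4 is estimated to give 2.5% in this assay, with a range from 0% to 15%.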

Compound 4, a percentage reported as activity, at one concentration (the size of the read-out at that concentration, not a potency): 5.25%
Estimate against measurement, compound 4: 2.8 percentage points below; the measured number falls inside the stated range.
By their numbers in this assay, from the lowest: compounds 1, 3, 4 and 2 (each within the scatter of the next, the first and the last beyond it).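

Among these compounds, compound 1 carries two methoxy groups, and the exchange in compound 4 removes the one that compound 3 leaves in place, so this result concerns a 4-methoxyphenyl group that the earlier compounds did not touch. In this assay, the change from 4-methoxyphenyl to phenyl gives a number 5 percentage points higher from compound 1 to compound 4 (within the scatter) and so shows no effect that can be told from the usual spread of repeated measurements. The methoxy at this position, on an aromatic carbon para to a large group, is therefore not needed for the low number seen with compound 1 at the single concentration tested, and nothing measured here explains why the number holds.

What an amine, a hydroxyl group or a longer chain such as butoxy would give on this carbon remains open, since hydrogen is the only replacement shown at this position. Also open, from the compounds shown here alone, is what happens when both methoxy groups are replaced in one compound, and how the compounds compare in potency, as a reading at one concentration does not give that.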